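This account rests on a few compounds, and the source may have more. Where it says the series, first, only, none or still open, it means among the compounds named here.

Measured so far in an ADME assay on microsomes from liver (Homo sapiens) for metabolic stability, read by LC-MS, with a stated time of 30 min, tested at 1 uM; a higher number here means that more of the compound is left, a lower number that less of the compound is left:

Compound 1 (`O=C(NCc1ccc(S(=O)(=O)c2ccccc2)cc1)c1nc2cnccc2[nH]1`): 73%
Compound 2 (`O=C(NCc1ccc(S(=O)(=O)N2CCCCC2)cc1)c1cc2cnccc2s1`): 15%
Compound 3 (`O=C(NCc1ccc(S(=O)(=O)c2ccccc2)cc1)c1cc(-c2cccnc2)no1`): 69%

Compound 1 at 73% and compound 3 at 69% lie within the scatter of each other. Compound 2 at 15% lies beyond the scatter from compound 1, with far less of the compound left. For the measured compounds named here, no two measured compounds differ in one place only, so the series offers no measured single-change step as a guide.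

The next compound to be read is compound 4 (`O=C(NCc1ccc(S(=O)(=O)c2ccccc2)cc1)c1ccc2nncn2c1`). It keeps everything in compound 1 except the group on a carbonyl carbon whose other neighbours are: amide-type nitrogen. The two structures have the same atoms, joined differently: a group of 9 heavy atoms (6 carbon, 3 nitrogen; one five-membered aromatic ring with 3 hetero atoms, one six-membered aromatic ring with 1 hetero atom) in place of a group of 9 heavy atoms (6 carbon, 3 nitrogen; one five-membered aromatic ring with 2 hetero atoms, one six-membered aromatic ring with 1 hetero atom), on a carbonyl carbon.

Compound 3 carries yet another group at that place and shares the rest of compound 1, and compound 3 still reads 69% in this assay. On that single comparison, only a small change is expected from the new group. The estimated step of a number 8 percentage points lower from compound 1 to compound 4 (within the scatter) is expected to be slightly downward and not beyond the scatter. For compound 4 the expected value is 65% in this assay, with an estimated range from 42% to 85% as the likely span of the measurement.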

Compound 4, percent of the compound remaining: 96%
Beside the measured number, compound 4's estimate is 31 percentage points below it; measured number above the stated range.
By their numbers in this assay, from the lowest: compound 2; then compounds 3 and 1 (each within the scatter of the next); then compound 4.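

At the place on a carbonyl carbon whose other neighbours are amide-type nitrogen, rejoining the same atoms is enough to move the reading in this assay (a number 23 percentage points higher from compound 1 to compound 4 (beyond the scatter)). For the compounds shown here, this is the first single-change step, and it shows that the assay responds to how this group is joined even with the same count of heavy atoms, carbon and nitrogen on both sides. The counted differences are that the group leaving has 1 hydrogen-bond donor and 2 hydrogen-bond acceptors, while the group entering has 0 donors and 3 acceptors, but no measurement shown links the step to either count or to any property of the two groups.

A single pair cannot separate the change in donor count from the change in how the two rings are joined. Still open, from the compounds shown here alone, is whether the entering group keeps its reading when it carries a methyl or an amine, and whether it does so with the piperidine sulfonyl part of compound 2 in place of the rest of compound 4.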